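A few compounds are considered here, and "the series" means these few. Any claim that something is new, unique, unknown or untested is made for them only; others in the source may bear on it.

Compound 1 `Cc1cnc(NC(=O)c2cc(Oc3cnc(C(=O)N(C)C)cn3)c3cc(C)oc3c2)cn1`: < 8.5 mL/min/kg (a limit)
Compound 2 `Cc1cnc(NC(=O)c2cc(Oc3cnc(C(=O)N4CCC4)cn3)c3cc(C)oc3c2)cn1`: < 9.3 mL/min/kg (a limit)
Compound 3 `Cc1cnc(NC(=O)c2cc(Oc3cnc(C(=O)N4CCCCC4)cn3)c3cc(C)oc3c2)cn1`: 18.2 mL/min/kg

In an ADME assay (liver) for metabolic stability, with Liver microsome (Homo sapiens) as the target, using microsomes (on this read-out lower numbers stand for slow clearance and higher numbers for fast clearance), compound 1 has no exact number, only the limit < 8.5 mL/min/kg. Compound 2 also gives only a limit, so compound 3 is the only one of the three with a true number.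

Compound 4 `Cc1cc2c(Oc3cnc(C(=O)N(C)C)cn3)cc(C(=O)Nc3cnccn3)cc2o1` keeps the core of compound 1 but has pyrazin-2-yl in place of 5-methylpyrazin-2-yl: hydrogen in place of methyl on an aromatic carbon. Within the data shown here, no measured step touches this methyl. All of them exchange the dimethylamino, azetidin-1-yl or piperidin-1-yl group on a carbonyl carbon: an at least 2.1-fold higher number from compound 1 to compound 3 (0.33 log units; beyond the scatter), an at least 1.9-fold higher number from compound 2 to compound 3 (0.29 log units; that floor lies within the scatter) and a step that the two limits leave unreadable from compound 1 to compound 2. These show that a single group can shift this assay, but they give no size for losing a methyl. With no direct evidence, no shift beyond the scatter is expected in either direction, so the expected change is a step that the limit leaves unreadable from compound 1 to compound 4. The estimated value for compound 4 is 8 mL/min/kg, with an expected range from 5 mL/min/kg to 16 mL/min/kg, and the assay may well report only a limit again.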

Compound 4, clearance: 15 mL/min/kg
Compound 4: the middle estimate sits 1.9-fold (0.27 log units) below what was measured; the measured number falls inside the stated range.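

Among these compounds, until now, every step in this assay came from exchanging the group on the carbonyl carbon, and compound 4 gives the first reading for a change on the aromatic carbon that carries the methyl of the 5-methylpyrazin-2-yl group. Hydrogen in place of that methyl gives an at least 1.7-fold higher number from compound 1 to compound 4 (0.24 log units; that floor lies within the scatter), so this change may or may not be a real rise. The true size of the step could be larger, because compound 1 has only a limit and not a number: the limit of < 8.5 mL/min/kg in this assay, at which 1 of the 4 values shown sits.

The compounds shown leave open how an ethyl group, a methoxy group or a chlorine atom would read on this carbon. They also leave open whether losing the methyl would read the same with azetidin-1-yl or piperidin-1-yl on the carbonyl carbon.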